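This account rests on a few compounds, and the source may have more. Where it says the series, first, only, none or still open, it means among the compounds named here.

In an ADME assay on MT4 cells (Homo sapiens) for cytotoxicity, read by MTT assay, with a stated time of 3 days (on this read-out higher numbers stand for lower toxicity in this test and lower numbers for higher toxicity in this test), compound 1 (`CC(C)(C)NC(=O)COC(=O)c1ccc([N+](=O)[O-])o1`) gives > 100000 nM as its result, and this is a limit of the assay and not a number. Compound 2 (`CC(C)(C)N(CCC(=O)c1ccccc1)C(=O)COC(=O)c1ccc([N+](=O)[O-])o1`) has no single number to stand on: compound 2 is recorded as "not active" (no number reported) in this assay and so offers only a result in words. Compound 3 (`CC(=O)Oc1ccccc1CN(C(=O)COC(=O)c1ccc([N+](=O)[O-])o1)C(C)(C)C`) has yet to be measured. The change leading to it is 2-acetoxyphenyl in place of benzoylmethyl on a saturated chain carbon bound to an amide-type nitrogen and puts 2-acetoxyphenyl in place of benzoylmethyl on a saturated chain carbon bound to an amide-type nitrogen. Within the data shown here, no measured step exists to size this change. Given that compound 2 is recorded as "not active" (no number reported) in this assay the expectation is no step beyond the scatter, in either direction. The estimated half-maximal cytotoxic concentration of compound 3 is 70000 nM (expected range 20000 nM to 100000 nM).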

Compound 3, half-maximal cytotoxic concentration: > 100000 nM
Compound 3 ended at the assay's limit; the forecaster's own chance of this, stated with the estimate: 55%; middle value at least 1.4-fold (0.15 log units) from the limit.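

Compound 2 has only a result in words and compound 3 stops at a limit of the assay, so no step can be read between them in this assay: the limit of > 100000 nM in this assay, at which 2 of the 3 values shown sit.

The compounds shown leave open whether exchanging benzoylmethyl for 2-acetoxyphenyl alters the half-maximal cytotoxic concentration at all.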